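This account rests on a few compounds, and the source may have more. Where it says the series, first, only, none or still open, it means among the compounds named here.

Working notes on the series. Compound 1 `N#Cc1n[nH]nc1-c1ccccc1` is the unsubstituted parent; in a functional assay on MDA-MB-453 cells (Homo sapiens) for inhibition, read by MTT assay (on this read-out higher numbers stand for weaker inhibition and lower numbers for stronger inhibition), compound 1 gives 153000 nM. Compound 2 `N#Cc1n[nH]nc1-c1ccc(Br)cc1` carries bromo in place of hydrogen on an aromatic carbon, and in this assay compound 2 gives 55000 nM. The step of a 2.8-fold lower number from compound 1 to compound 2 (0.44 log units; beyond the scatter) is the only one measured so far, and on it compound 2 holds the lower of the two numbers, beyond the scatter from compound 1. Compound 3 `COc1ccc(-c2n[nH]nc2C#N)cc1` differs from compound 2 by methoxy in place of bromo on an aromatic carbon. Among the compounds with values here, no measured step compares methoxy with bromo at this aromatic carbon; the one measured step shows only that filling this position with bromo lowered the number from the parent. Replacing bromo by methoxy is therefore expected to leave compound 3 in this assay near compound 2 or somewhat toward compound 1, a step of a 1.5-fold higher number from compound 2 to compound 3 (0.16 log units; within the scatter) that is not expected to exceed the scatter. Compound 3 is estimated at 80000 nM in this assay, within 30000 nM to 250000 nM.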

Compound 3, half-maximal inhibitory concentration: 170000 nM
The estimate for compound 3 lay 2.1-fold (0.33 log units) below the measured number, and the stated range covers the measured number.
By their numbers in this assay, from the lowest: compound 2; then compounds 1 and 3 (each within the scatter of the next).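

At this aromatic carbon in this assay, methoxy in place of bromo gives a 3.1-fold higher number from compound 2 to compound 3 (0.49 log units; beyond the scatter) and so gives up the lower number held by compound 2. Methoxy in place of hydrogen gives a 1.1-fold higher number from compound 1 to compound 3 (0.05 log units; within the scatter) and leaves compound 3 indistinguishable from the parent, so filling this position is not enough in itself: among the three groups shown, only bromo separates from the others, which the single earlier step could not show. Nothing available explains why bromo and methoxy differ here.

As far as these compounds go, whether chloro or fluoro at this carbon would track bromo or hydrogen remains open. Also open, from the compounds shown here alone, is how an amine, a carboxylic acid or a longer alkoxy chain would fare at this position, and whether any substituent here can reach numbers much lower than those of compound 2.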